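The compounds below may be only part of what the source reports. "The series", "measured", "known", "first", "only" and "open" are said of these compounds alone.

Four compounds share one core and differ in two places. Compound 1 `CN(C)c1ncnc2c1c(-c1ccoc1)cn2[C@@H]1O[C@H](CO)[C@@H](O)[C@H]1O` carries a dimethylamino group and a furan-3-yl group; in a functional assay on HepG2 cells (Homo sapiens) for antiproliferative activity, read by XTT assay, with a stated time of 72 h (on this read-out higher numbers stand for weaker inhibition and lower numbers for stronger inhibition), compound 1 gives 12500 nM. Compound 2 `CSc1ncnc2c1c(-c1ccoc1)cn2[C@@H]1O[C@H](CO)[C@@H](O)[C@H]1O` carries a methylsulfanyl group instead. In this assay compound 2 reaches only a limit, > 15000 nM. Compound 3 `CSc1ncnc2c1c(-c1cccs1)cn2[C@@H]1O[C@H](CO)[C@@H](O)[C@H]1O` keeps the methylsulfanyl group and carries a thiophen-2-yl group. In this assay compound 3 likewise reaches only a limit, > 20000 nM.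

On these data alone, the change dimethylamino in place of methylsulfanyl on an aromatic carbon gave an at least 1.2-fold lower number from compound 2 to compound 1 (0.07 log units; that floor lies within the scatter); its true size stays open because of the limit of > 15000 nM in this assay, at which 1 of the 3 values shown sits. The two cores differ by thiophen-2-yl in place of furan-3-yl on an aromatic carbon, and a step that the two limits leave unreadable from compound 2 to compound 3, bounded by the limit of > 15000 nM in this assay, at which 1 of the 3 values shown sits, and (the limit of > 20000 nM in this assay, at which 1 of the 3 values shown sits).

Compound 4 `CN(C)c1ncnc2c1c(-c1cccs1)cn2[C@@H]1O[C@H](CO)[C@@H](O)[C@H]1O` is not yet measured. It differs from compound 3 by dimethylamino in place of methylsulfanyl on an aromatic carbon, the same change at the same place as from compound 2 to compound 1. The expectation rests on compound 1 at 12500 nM and on the step of an at least 1.2-fold lower number from compound 2 to compound 1 (0.07 log units; that floor lies within the scatter). Compound 4 is therefore expected to show an at least 1.2-fold lower number from compound 3 to compound 4 (0.09 log units; that floor lies within the scatter) in this assay. Compound 4 is estimated at 16000 nM, between 8000 nM and 30000 nM.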

Compound 4, half-maximal inhibitory concentration: > 20000 nM
Compound 4 ended at the assay's limit; the forecaster's own chance of this, stated with the estimate: 55%; at least 1.2-fold (0.09 log units) between middle value and limit.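

Carrying dimethylamino in place of methylsulfanyl over to the thiophen-2-yl core gives no readable result in this assay, because compound 3 and compound 4 both stop at the same limit rather than at a true number: the limit of > 20000 nM in this assay, at which 2 of the 4 values shown sit. The same swap on the furan-3-yl core gave only a small floor that stays within the scatter, so the thiophen-2-yl pair neither confirms nor contradicts a transfer of that change from one core to the other. With dimethylamino held fixed, thiophen-2-yl in place of furan-3-yl gives an at least 1.6-fold higher number from compound 1 to compound 4 (0.20 log units; that floor lies within the scatter), so this comparison does not establish a real difference between the two cores either.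

The compounds shown leave open how a primary amino group or a methoxy group on that same aromatic carbon would read in this assay. They also leave open whether a phenyl group in place of furan-3-yl or thiophen-2-yl would give a true number rather than a limit.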